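The source may report more compounds than this note shows. Statements on the series, on what has been measured and on what is new or still open speak of the compounds shown alone.

Measured so far in a functional assay (Pituitary gland cell) with Rattus norvegicus as the target; on this read-out higher numbers stand for an effect only at larger amounts of compound and lower numbers for an effect already at smaller amounts:
compound 1 `CC(C)(N)C(=O)N[C@@H]1CCc2ccccc2N(Cc2ccc(-c3ccccc3-c3nn[nH]n3)cc2)C1=O` gives 30 nM;
compound 2 `C[C@@H](O)CCNC(C)(C)C(=O)N[C@@H]1CCc2ccccc2N(Cc2ccc(-c3ccccc3-c3nn[nH]n3)cc2)C1=O` gives 100 nM.

Compound 2 holds the higher of the two numbers, and the step of a 3.3-fold higher number from compound 1 to compound 2 (0.52 log units; beyond the scatter) is the only measured one. Compound 3 `CC(=O)O[C@@H](C)CNC(C)(C)CC(=O)N[C@@H]1CCc2ccccc2N(Cc2ccc(-c3ccccc3-c3nn[nH]n3)cc2)C1=O` differs from compound 2 in one place: 2-((2-acetoxypropyl)amino)-2-methylpropyl in place of 1-((3-hydroxybutyl)amino)-1-methylethyl on a carbonyl carbon. Among the measured compounds shown here, no measured step covers this exact change; the one step known, from compound 1 to compound 2, shows that enlarging this side chain moved the number upward modestly. A further change on the same chain is therefore expected to shift the number modestly again, a 1.5-fold higher number from compound 2 to compound 3 (0.18 log units; within the scatter), in the same direction or by little. Compound 3 is estimated at 150 nM, with a range from 40 nM to 600 nM.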

Compound 3, concentration for half-maximal effect: 200 nM
For compound 3 the middle estimate is 1.3-fold (0.12 log units) below the measured one; the range from low to high includes it.
By their numbers in this assay, from the lowest: compound 1; then compounds 2 and 3 (each within the scatter of the next).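

In this assay, putting 2-((2-acetoxypropyl)amino)-2-methylpropyl in place of 1-((3-hydroxybutyl)amino)-1-methylethyl on the carbonyl carbon stays within the scatter (a 2.0-fold higher number from compound 2 to compound 3 (0.30 log units; within the scatter)), so this second, differently built chain reads no differently from the first. Measured against the small 1-amino-1-methylethyl group, the new chain gives a step beyond the scatter (a 6.7-fold higher number from compound 1 to compound 3 (0.82 log units; beyond the scatter)). Nothing available explains either step.

From the compounds shown here alone, the whole chain changes at once, so the share of the acetoxy group alone stays unknown. Going by these compounds, how a carboxylic acid or a plain hydroxyl on this chain would read remains open.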